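Hydroxyl position shift from compound 3 to compound 4

The source may report more compounds than this note shows. Statements on the series, on what has been measured and on what is new or still open speak of the compounds shown alone.

Compound 1, `Oc1cccc(-c2cc(-c3ccccc3F)cc(-c3cccc(O)c3)n2)c1`, gives 5300 nM in a functional assay on HCT-15 cells (Homo sapiens) for inhibition; on this read-out lower numbers stand for stronger inhibition and higher numbers for weaker inhibition.
Compound 2, `Oc1cccc(-c2cc(-c3cccc(F)c3)cc(-c3cccc(O)c3)n2)c1`, gives 7860 nM in this assay.
Compound 3, `Oc1cccc(-c2cc(-c3ccccc3C(F)(F)F)cc(-c3ccccc3O)n2)c1`, gives 9010 nM in this assay.

Compound 3 holds the highest of the three numbers, but its gaps to compound 2 and to compound 1 both lie within the scatter, so no order among them can be read. Compound 4, `Oc1cccc(-c2cc(-c3ccccc3C(F)(F)F)cc(-c3cccc(O)c3)n2)c1`, differs from compound 3 by 3-hydroxyphenyl in place of 2-hydroxyphenyl on an aromatic carbon. Within the data shown here, the only measured one-point step, a 1.5-fold higher number from compound 1 to compound 2 (0.17 log units; within the scatter), concerns the fluorine position on the other aryl group and does not touch the hydroxyl position; no measured pair isolates this change. The values of compound 1, compound 2 and compound 3 all sit within the scatter of one another, so the series shows no response to these substitutions. Compound 4 is therefore expected to show no step beyond the scatter, i.e. a 1.4-fold lower number from compound 3 to compound 4 (0.14 log units; within the scatter). Compound 4 is estimated at 6500 nM, within 2500 nM to 16000 nM.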

Compound 4, half-maximal inhibitory concentration: 8150 nM
Compound 4: middle estimate off by 1.3-fold (0.10 log units), on the low side; the range from low to high includes it.
By their numbers in this assay, from the lowest: compounds 1, 2, 4 and 3 (each within the scatter of the next).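

In this assay, among these compounds, 3-hydroxyphenyl in place of 2-hydroxyphenyl gives a 1.1-fold lower number from compound 3 to compound 4 (0.04 log units; within the scatter); this is the first measured pair to isolate the hydroxyl position, and that position shows no readable effect. On the other aryl group, 2-(trifluoromethyl)phenyl in place of 3-fluorophenyl gives a 1.0-fold higher number from compound 2 to compound 4 (0.02 log units; within the scatter), and trifluoromethyl in place of fluoro gives a 1.5-fold higher number from compound 1 to compound 4 (0.19 log units; within the scatter), so neither change separates from the scatter. Nothing available explains this lack of response. Still open, from the compounds shown here alone, is whether an amine or a carboxylic acid in place of either hydroxyl would produce a step beyond the scatter.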